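A few compounds are considered here, and "the series" means these few. Any claim that something is new, unique, unknown or untested is made for them only; others in the source may bear on it.

In a functional assay on DU-145 cells (Homo sapiens) for inhibition, read by trypan blue exclusion, with a stated time of 96 h (a higher number here means a weaker inhibitor of growth, a lower number a stronger inhibitor of growth), compound 1 `Cc1ccsc1/C=C(/SCc1ccc(Cl)cc1)C(=O)c1ccc(Cl)cc1` gives 50000 nM. Compound 2 `Cc1ccc(S(=O)(=O)/C(=C/c2ccc(C)s2)C(=O)c2ccc(Br)cc2)cc1` gives 25000 nM, within the scatter of compound 1, while compound 3 `O=C(/C(=C\c1ccc(O)c([N+](=O)[O-])c1)SCc1ccc(Cl)cc1)c1ccc(Cl)cc1` gives 10000 nM. Compound 4 `Cc1ccsc1/C=C(/SCc1ccc(Cl)c(Cl)c1)C(=O)c1ccc(Cl)cc1` departs from compound 1 by a single change, chloro in place of hydrogen on an aromatic carbon, which turns 4-chlorobenzyl into 3,4-dichlorobenzyl. For the measured compounds named here, the one measured step, a 5.0-fold lower number from compound 1 to compound 3 (0.70 log units; beyond the scatter), replaces 3-methylthiophen-2-yl and leaves the 4-chlorobenzyl group untouched, so it bears only indirectly on this change. Going by the values given here, no measured step covers this change, and no shift beyond the scatter is expected in this assay. Compound 4 is estimated at 30000 nM, with an expected range of 8000 nM to 100000 nM. The estimated step is a 1.7-fold lower number from compound 1 to compound 4 (0.22 log units; within the scatter).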

Compound 4, concentration for 50% growth inhibition: 50000 nM
Compound 4: the middle estimate sits 1.7-fold (0.22 log units) below what was measured, and the stated range covers the measured number.
By their numbers in this assay, from the lowest: compound 3; then compounds 2, 1 and 4 (each within the scatter of the next).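

In this assay, chloro in place of hydrogen, turning 4-chlorobenzyl into 3,4-dichlorobenzyl, gives no change at the digits printed from compound 1 to compound 4 (within the scatter). For the compounds shown here, compound 1 and compound 3 share 4-chlorobenzyl, so only this step shows that this aromatic carbon, ortho to a chloro group, accepts a second chloro without a shift beyond the scatter. No available evidence explains this result. On these data alone, whether a methoxy group or an amine on this carbon would leave the number equally unmoved remains open. So does whether 3,4-dichlorobenzyl would behave alike alongside the 4-hydroxy-3-nitrophenyl group of compound 3.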